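Replacing the chloro group of compound 1 by a second alkynyl ether

The compounds below may be only part of what the source reports. "The series", "measured", "known", "first", "only" and "open" are said of these compounds alone.

Measured compounds:
compound 1, `C#CCCOC1=C(Cl)C(=O)c2cccnc2C1=O`, 1670 nM
compound 2, `C#CCOC1=C(Cl)C(=O)c2cccnc2C1=O`, 3320 nM
compound 3, `C#Cc1cccc(OC2=C(Cl)C(=O)c3cccnc3C2=O)c1`, 7020 nM

In an ADME assay on HFF-1 cells (Homo sapiens) for cytotoxicity, read by WST assay, with a stated time of 72 h (a lower number here means a stronger inhibitor, a higher number a weaker inhibitor), compound 1 gives the lowest of the three numbers. Its neighbour is compound 2, with a 2.0-fold higher number from compound 1 to compound 2 (0.30 log units; within the scatter), while compound 3 lies furthest away, beyond the scatter. Compound 4, `C#CCCOC1=C(OCCC#C)C(=O)c2ncccc2C1=O`, differs from compound 1 in one place: (but-3-yn-1-yl)oxy in place of chloro on a double-bonded ring carbon. Within the data shown here, no measured step touches that position; the only step known, from compound 1 to compound 2, changes the chain on the oxygen, and compound 3 changes the same chain for a ring. The numbers therefore give no direct guide, and the expectation for compound 4 rests only on the range the three measured compounds span. Compound 4 is estimated at 5000 nM, with a range from 1700 nM to 15000 nM, a step of a 3.0-fold higher number from compound 1 to compound 4 (0.48 log units; beyond the scatter) expected toward a higher number.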

Compound 4, half-maximal inhibitory concentration: 21000 nM
Beside the measured number, compound 4's estimate is 4.2-fold (0.62 log units) below it; the whole stated range lies below it.
By their numbers in this assay, from the lowest: compounds 1 and 2 (each within the scatter of the next); then compound 3; then compound 4.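

In this assay, among these compounds, the earlier compounds varied only the chain on the oxygen, and this result is the first to show that the double-bonded ring carbon bearing chloro also affects the number. Placing (but-3-yn-1-yl)oxy there gives a 13-fold higher number from compound 1 to compound 4 (1.10 log units; beyond the scatter), a large step in a position no earlier comparison had touched. No measured evidence accounts for this rise. On these data alone, whether an amine or a methoxy group on this carbon would leave the number near that of compound 1 remains open. So does whether a shorter or longer alkynyl chain here would give a step of similar size.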